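Swapping 2-bromophenyl for 4-chlorophenyl on a shared core

A few compounds are considered here, and "the series" means these few. Any claim that something is new, unique, unknown or untested is made for them only; others in the source may bear on it.

Compound 1 `COc1ccc(/C=C(\C)C(=O)/C=C/c2ccc(F)cc2)cc1` gives 68100 nM
Compound 2 `COc1ccc(/C=C(\C)C(=O)/C=C/c2ccccc2Br)cc1` gives 71000 nM
Compound 3 `COc1ccc(/C=C(\C)C(=O)/C=C/c2ccc(Cl)cc2)cc1` is not yet measured

Both values come from an ADME assay on Vero cells (Chlorocebus sabaeus) for cytotoxicity, read by MTT assay, with a stated time of 72 h (a lower number here means that less compound is tolerated, a higher number that more compound is tolerated), and compound 2 stands level with compound 1 within the scatter. Going on to compound 3, 4-chlorophenyl replaces 2-bromophenyl 4-chlorophenyl in place of 2-bromophenyl on a double-bonded chain carbon bound to a double-bonded chain carbon on a double-bonded chain carbon bound to a double-bonded chain carbon. Going by the values given here, the only measured step at that place, which put 2-bromophenyl where 4-fluorophenyl stood, is a 1.0-fold higher number from compound 1 to compound 2 (0.02 log units; within the scatter) and stayed within the scatter, so no step beyond the scatter is expected in this assay here. An estimated 1.1-fold lower number from compound 2 to compound 3 (0.06 log units; within the scatter) is expected. For compound 3 the estimate is 62000 nM within an expected range of 28000 nM to 120000 nM.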

Compound 3, half-maximal cytotoxic concentration: 87000 nM
Compound 3: the middle estimate sits 1.4-fold (0.15 log units) below what was measured, within the range that was stated.
By their numbers in this assay, from the lowest: compounds 1, 2 and 3 (each within the scatter of the next).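

In this assay, 4-chlorophenyl in place of 2-bromophenyl gives a 1.2-fold higher number from compound 2 to compound 3 (0.09 log units; within the scatter) and chloro in place of fluoro on an aromatic carbon gives a 1.3-fold higher number from compound 1 to compound 3 (0.11 log units; within the scatter) on the shared core. All three halogen-bearing phenyl groups therefore stand level, so swapping the halogen or its place on this phenyl group has not yet produced a step beyond the scatter. Nothing measured explains this level result.

Still open, going by these compounds, is whether a different kind of group at this place, such as an amine or a carboxylic acid on the phenyl ring, would move the number beyond the scatter.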